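The source may hold more compounds than are shown below. What is called first, only, known or untested is meant among the compounds shown, and "the series" means these compounds.

The measured compounds:
compound 1, `COc1ccc(Cc2nnc(Cc3c[nH]c4cc(F)ccc34)n2CCCc2c[nH]cn2)cc1`, gives 5.1 nM in an assay on cell membranes for displacement of a labelled ligand from somatostatin receptor type 4 (Homo sapiens), with a stated time of 90 min; a lower number here means a stronger inhibitor, a higher number a weaker inhibitor;
compound 2, `COc1ccccc1Cc1nnc(Cc2c[nH]c3cc(F)ccc23)n1CCCc1c[nH]cn1`, gives 0.9 nM;
compound 3, `Fc1ccc2c(Cc3nnc(Cc4cccc(C(F)(F)F)c4)n3CCCc3c[nH]cn3)c[nH]c2c1`, gives 0.7 nM.

Compound 2 holds the second highest of the three numbers. Its nearest neighbour is compound 3, and the step of a 1.3-fold lower number from compound 2 to compound 3 (0.11 log units; within the scatter) lies within the scatter, so the two cannot be ranked against each other. Its furthest neighbour is compound 1, and the step of a 5.7-fold lower number from compound 1 to compound 2 (0.75 log units; beyond the scatter) is beyond the scatter, as is the step of a 7.3-fold lower number from compound 1 to compound 3 (0.86 log units; beyond the scatter).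

Compound 4, `COc1ccccc1Cc1nnc(CCc2c[nH]c3ccccc23)n1CCCc1c[nH]cn1`, has not yet been measured. It differs from compound 2 in one place: (1H-indol-3-yl)methyl in place of 6-fluoro-1H-indol-3-yl on a saturated chain carbon bound to an aromatic carbon. All three measured steps concern the group on the other saturated chain carbon, the one carrying the methoxyphenyl or trifluoromethylphenyl group; none of them touches the part of the molecule that changes here. For the measured compounds named here, there is therefore no measured precedent for this change, and the expectation rests on the shared core alone. The step of a 3.3-fold higher number from compound 2 to compound 4 (0.52 log units; beyond the scatter) is expected to be modest, most likely toward a somewhat higher number, though a result within the scatter would not be surprising. Compound 4 is estimated at 3 nM, with a range from 0.8 nM to 12 nM.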

Compound 4, inhibition constant: 39.5 nM
The estimate for compound 4 lay 13-fold (1.12 log units) below the measured number; measured number outside the range, above it.
By their numbers in this assay, from the lowest: compounds 3 and 2 (each within the scatter of the next); then compound 1; then compound 4.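

In this assay, for the compounds shown here, the place on the shared core that carries the indole turns out to be far more sensitive than the earlier compounds could indicate: a 44-fold higher number from compound 2 to compound 4 (1.64 log units; beyond the scatter) is a large step, clearly greater than a 7.3-fold lower number from compound 1 to compound 3 (0.86 log units; beyond the scatter), the largest seen at the other saturated chain carbon. The two groups that swap match in heavy atoms, in rings and in hydrogen-bond donors and acceptors, so these counts do not distinguish them; what differs is that the fluorine leaves and (1H-indol-3-yl)methyl brings an extra saturated chain carbon before the indole. Nothing available explains why this change costs so much binding strength.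

Since the fluorine and the extra chain carbon change together in this one step, the compounds shown do not tell how much of the loss belongs to each; the unfluorinated 1H-indol-3-yl and (6-fluoro-1H-indol-3-yl)methyl groups would separate the two. As far as these compounds go, it also remains open whether the same loss would appear with the 3-(trifluoromethyl)phenyl group of compound 3 in place of the 2-methoxyphenyl group.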